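Compound 1 to compound 4: carbamoyl for trifluoromethoxy

This account rests on a few compounds, and the source may have more. Where it says the series, first, only, none or still open, it means among the compounds named here.

Compound 1 `Cc1cc(NC(=O)Nc2ccccc2OC(F)(F)F)c2ccccc2n1` gives > 25000 nM in an ADME assay on HepG2 cells (Homo sapiens) for cytotoxicity, with a stated time of 72 h (a lower number here means that less compound is needed, a higher number that more compound is needed for the effect), which is a limit of the assay and not a number. Compound 3 `Cc1cc(NC(=O)Nc2cnc3ccccc3c2)c2ccccc2n1` gives > 25000 nM, also a limit. Among the measured compounds shown here, compound 2 `CCc1ccc(NC(=O)Nc2cc(C)nc3ccccc23)cc1` gives 17000 nM, the only true number so far. The standing of compound 1 is therefore (the limit of > 25000 nM in this assay, at which 2 of the 3 values shown sit).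

Compound 4 `Cc1cc(NC(=O)Nc2ccccc2C(N)=O)c2ccccc2n1` has carbamoyl in place of trifluoromethoxy on an aromatic carbon, ortho to a large group: carbamoyl in place of trifluoromethoxy on an aromatic carbon. For the measured compounds named here, the series offers no measured step between compounds that differ in one place, so the effect of this change in this assay cannot be read directly. No step beyond the usual scatter is expected, and no direction is favoured. A reading at the limit is the most likely outcome. Compound 2 at 17000 nM serves as the reference for the lower end of the range. Compound 4 is estimated at 30000 nM, with an expected range of 15000 nM to 60000 nM. The expected change is a step that the limit leaves unreadable from compound 1 to compound 4.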

Compound 4, half-maximal effective concentration: > 25000 nM
Compound 4 gave a limit, no number; the forecaster's own chance of this, stated with the estimate: 80%; the middle value lies beyond the limit too.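

Among the compounds shown here, compound 1 and compound 4 both stand as limits in this assay and not as numbers, and no step between them can be read. The compounds shown leave open whether carbamoyl in place of trifluoromethoxy changes this read-out at all, with most readings at one value: the limit of > 25000 nM in this assay, at which 3 of the 4 values shown sit.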